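The source may hold more compounds than are shown below. What is called first, only, known or untested is meant among the compounds shown, and "the series" means these compounds.

Compound 1 `Cc1nc(NCC2CC2)nc(N[C@@H]2C[C@H](CO)[C@@H](O)[C@H]2O)c1-c1nc2ccccc2s1` is one of three compounds whose exposure after oral dosing has been measured in an ADME assay on the whole organism (plasma) for pharmacokinetics, with Rattus norvegicus as the target, with a stated time of 6 h, at a dose of 10 mg/kg by the oral route; a higher number here means more compound in the circulation at the dose given, a lower number less compound in the circulation. In this assay compound 1 gives 1410 ng.h/mL, which puts it second highest of the three numbers. Its nearest neighbour is compound 3 `Cc1nc(NCCC(F)(F)F)nc(N[C@@H]2C[C@H](CO)[C@@H](O)[C@H]2O)c1-c1nc2ccccc2s1`, which gives 2560 ng.h/mL; the step of a 1.8-fold higher number from compound 1 to compound 3 (0.26 log units; within the scatter) is within the usual scatter. Furthest away is compound 2 `Cc1nc(NCC2CCC2)nc(N[C@@H]2C[C@H](CO)[C@@H](O)[C@H]2O)c1-c1nc2ccccc2s1`, which gives 228 ng.h/mL; the step of a 6.2-fold lower number from compound 1 to compound 2 (0.79 log units; beyond the scatter) is beyond the scatter, and between those two the step of an 11-fold higher number from compound 2 to compound 3 (1.05 log units; beyond the scatter) is large.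

Compound 4 `Cc1nc(NCc2ccsc2)nc(N[C@@H]2C[C@H](CO)[C@@H](O)[C@H]2O)c1-c1nc2ccccc2s1` differs from compound 1 in one place: thiophen-3-yl in place of cyclopropyl on a saturated chain carbon bound to a nitrogen on an aromatic ring. Going by the values given here, no measured step covers a thiophen-3-yl group at this position, so the expectation rests on the two steps that do exchange the group on this saturated chain carbon. One of them, a 6.2-fold lower number from compound 1 to compound 2 (0.79 log units; beyond the scatter), shows that a change here can lower the number well beyond the scatter; the other, a 1.8-fold higher number from compound 1 to compound 3 (0.26 log units; within the scatter), shows a change here can also leave the number essentially unchanged. The entering group is the larger of the two by the count given, which leans the estimate toward a lower number, with wide uncertainty. Compound 4 is therefore expected to give 600 ng.h/mL in this assay, within a range from 150 ng.h/mL to 2400 ng.h/mL, a step of a 2.4-fold lower number from compound 1 to compound 4 (0.37 log units; beyond the scatter) that is expected rather than known.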

Compound 4, area under the concentration-time curve: 96.7 ng.h/mL
Compound 4: middle estimate off by 6.2-fold (0.79 log units), on the high side; the whole stated range lies above it.
By their numbers in this assay, from the lowest: compound 4; then compound 2; then compounds 1 and 3 (each within the scatter of the next).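

In this assay, placing thiophen-3-yl on this saturated chain carbon produces the widest gaps yet seen at this position, with a 15-fold lower number from compound 1 to compound 4 (1.16 log units; beyond the scatter) and a 26-fold lower number from compound 3 to compound 4 (1.42 log units; beyond the scatter) as the two largest steps. Even the cyclobutyl group, which had given the lowest number so far, is not the floor, since the change to thiophen-3-yl gives a 2.4-fold lower number from compound 2 to compound 4 (0.37 log units; beyond the scatter) as a further modest fall, so among the three ring groups shown, cyclobutyl and thiophen-3-yl both sit well under cyclopropyl, while compound 3, which carries 2,2,2-trifluoroethyl and no ring, stays within the scatter of compound 1. No measurement presented here explains why the number falls so far with this change.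

Compound 4 differs from compound 2 in both ring size and aromatic character, so the compounds shown cannot tell which of these goes with the lower number, and a phenyl ring or a cyclopentyl ring at this position would help to separate them. On these data alone, it also remains open whether an open chain without fluorine, such as propyl, would stay close to compound 1 as compound 3 does, or fall as the larger rings do.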